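A few compounds are considered here, and "the series" means these few. Any claim that something is new, unique, unknown or untested is made for them only; others in the source may bear on it.

Compound 1 `N#CC1CN1C(=O)Nc1ccc(Cl)c(Cl)c1` gives 4600 nM in a functional assay on MCF7 cells (Homo sapiens) for inhibition; on this read-out higher numbers stand for weaker inhibition and lower numbers for stronger inhibition.
Compound 2 `N#CC1CN1C(=O)Nc1ccc(F)cc1` gives 1900 nM in this assay.

Of these two numbers, compound 2 has the lower one, and its gap to compound 1 lies beyond the usual scatter. Compound 3 `CCOC(=O)c1ccc(NC(=O)N2CC2C#N)cc1` follows from compound 2 by one change: ethoxycarbonyl in place of fluoro on an aromatic carbon. Among the measured compounds shown here, no measured pair shows a change of this kind, so there is no earlier step to lean on. The expected step is small, toward a somewhat higher number, and may not exceed the scatter: a 1.3-fold higher number from compound 2 to compound 3 (0.12 log units; within the scatter). Compound 3 is expected to give about 2500 nM in this assay, within 800 nM to 8000 nM.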

Compound 3, half-maximal inhibitory concentration: 2300 nM
Compound 3: the middle estimate sits 1.1-fold (0.04 log units) above what was measured; low and high end bracket the measured number.
By their numbers in this assay, from the lowest: compounds 2, 3 and 1 (each within the scatter of the next, the first and the last beyond it).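

Putting ethoxycarbonyl, with five heavy atoms and a double bond outside the ring, in place of the single fluoro atom gives a 1.2-fold higher number from compound 2 to compound 3 (0.08 log units; within the scatter) in this assay. This position on the aromatic ring therefore accepts a much larger group that brings hydrogen-bond acceptors, with no step beyond the scatter. No measurement shown here accounts for this outcome.

Going by these compounds, whether a carboxylic acid or an amine at this position would also stay this close to compound 2 remains open. So does the effect of a longer chain on the ester.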